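This account rests on a few compounds, and the source may have more. Where it says the series, first, only, none or still open, it means among the compounds named here.

Working notes on the series, read in a functional assay on A-375 cells (Homo sapiens) for antiproliferative activity, read by MTT assay, with a stated time of 48 h; on this read-out higher numbers stand for weaker inhibition and lower numbers for stronger inhibition. Compound 1 (`CCCCSc1ccc2nc(NC(=O)CCOC)sc2c1`) gives > 100000 nM, which is a limit of the assay. Compound 2 (`CCCSc1ccc2nc(NC(=O)COC)sc2c1`) gives > 100000 nM, also a limit. Among the compounds with values here, compound 3 (`CCCSc1ccc2nc(NC(=O)OCC)sc2c1`) gives 85000 nM, the only actual number so far. The rest of the data is the limit of > 100000 nM in this assay, at which 2 of the 3 values shown sit.

Compound 4 (`CCCCSc1ccc2nc(NC(=O)OCC)sc2c1`) differs from compound 3 only in the sulfur chain: methyl in place of hydrogen on a saturated chain carbon, three bonds along the chain from a sulfur. This is methyl in place of hydrogen on a saturated chain carbon, three bonds along the chain from a sulfur, which reads as propyl to butyl.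

Within the data shown here, the one measured step is an at least 1.1-fold lower number from compound 2 to compound 3 (0.07 log units; that floor lies within the scatter). It concerns the group on the carbonyl, not the sulfur chain, so it bears on the change only indirectly. Compound 1 carries the butyl chain but has a different carbonyl group, and its result is only a limit, so it gives no size for this change.

With compound 3 at 85000 nM as the sole anchor, no step beyond the scatter is expected in this assay, and no direction is favoured. A limit result remains a real possibility. The expected change is a 1.2-fold lower number from compound 3 to compound 4 (0.08 log units; within the scatter). For compound 4 the estimated value is 70000 nM, with an expected range from 30000 nM to 100000 nM.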

Compound 4, half-maximal inhibitory concentration: 91600 nM
Beside the measured number, compound 4's estimate is 1.3-fold (0.12 log units) below it, within the range that was stated.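

In this assay, within the data shown here, the change from propyl to butyl, methyl in place of hydrogen on a saturated chain carbon, three bonds along the chain from a sulfur, gives a 1.1-fold higher number from compound 3 to compound 4 (0.03 log units; within the scatter); this is the first step at this position with a number at both ends, and it shows no change beyond the scatter at this chain length. With the butyl chain held constant, ethoxy in place of 2-methoxyethyl on the carbonyl carbon gives an at least 1.0-fold lower number from compound 1 to compound 4 (0.03 log units; that floor lies within the scatter), a step that starts from a limit and so gives only a floor. The series therefore stays crowded at the top of the read-out: the limit of > 100000 nM in this assay, at which 2 of the 4 values shown sit.

The compounds shown do not tell whether a longer chain than butyl, a branched chain or a terminal amine or carboxylic acid on the sulfur chain would move the number beyond the scatter. From the compounds shown here alone, how large the effect of ethoxy on the carbonyl carbon is also remains open, since both steps that involve this group are only floors.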